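A naphthyl group in place of the aryl ether

This account rests on a few compounds, and the source may have more. Where it says the series, first, only, none or still open, it means among the compounds named here.

Compound 1 `COc1ccc(Oc2ccc3c(NCCCNCc4cc(F)ccc4OC)ccnc3c2)cc1` gives 9.28 in a physicochemical assay for acid dissociation. Compound 2 `COc1ccc(F)cc1CNCCCNc1ccnc2cc(Oc3ccccc3)ccc12` gives 9.28 in this assay, and compound 3 `COc1ccc(F)cc1CNCCCNc1ccnc2cc(Oc3ccc(Cl)cc3)ccc12` gives 9.28 in this assay. The three values are level at the digits shown: no change at the digits printed from compound 1 to compound 2 (within the scatter), no change at the digits printed from compound 1 to compound 3 (within the scatter) and no change at the digits printed from compound 2 to compound 3 (within the scatter). Compound 4 `COc1ccc(F)cc1CNCCCNc1ccnc2cc(-c3cccc4ccccc34)ccc12` differs from compound 3 in one place: naphthalen-1-yl in place of 4-chlorophenoxy on an aromatic carbon. All three measured steps alter the same part of the structure and leave the acid dissociation constant untouched, and the change to compound 4 again touches only that part. The expected step is therefore none beyond the scatter, no change at the digits printed from compound 3 to compound 4 (within the scatter). Compound 4 is estimated at 9.28 in this assay, with a range from 8.9 to 9.7.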

Compound 4, acid dissociation constant: 9.47
Compound 4: middle estimate off by 0.19 log units, on the low side; low and high end bracket the measured number.
By their numbers in this assay, from the lowest: compounds 1, 2, 3 and 4 (each within the scatter of the next).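

In this assay, naphthalen-1-yl in place of the phenoxy groups gives a number 0.19 log units higher from compound 3 to compound 4 (within the scatter), a number 0.19 log units higher from compound 2 to compound 4 (within the scatter) and a number 0.19 log units higher from compound 1 to compound 4 (within the scatter). The earlier compounds shown here varied only the substituent on a phenoxy group, whereas these steps replace 4-chlorophenoxy, phenoxy and 4-methoxyphenoxy with an all-carbon group of 2 six-membered aromatic rings, and every step stays within the scatter. Nothing available explains this reading. Going by these compounds, whether an amine or a carboxylic acid on this aromatic carbon would also stay within the scatter remains open, as does the outcome of any change elsewhere in these compounds.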